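A few compounds are considered here, and "the series" means these few. Any claim that something is new, unique, unknown or untested is made for them only; others in the source may bear on it.

Compound 1 `CC(=O)OC[C@H]1CN(c2ccc(-n3cc(-c4ccccn4)cn3)c(F)c2)C(=O)O1`: in an ADME assay on L02 cells (Homo sapiens) for cytotoxicity, read by MTT assay, with a stated time of 48 h (on this read-out higher numbers stand for weaker inhibition and lower numbers for stronger inhibition), compound 1 reports only the limit > 400 ug/mL.
Compound 2 `O=C1O[C@@H](Cn2ccnn2)CN1c1ccc(-n2cc(-c3ccccn3)cn2)c(F)c1`: in this assay compound 2 gives 49 ug/mL.

Within the data shown here, compound 2 holds the only plain number in this assay; the other value shown is a limit. Compound 3 `O=CNC[C@H]1CN(c2ccc(-n3cc(-c4ccccn4)cn3)c(F)c2)C(=O)O1` differs from compound 2 by formylamino in place of 1H-1,2,3-triazol-1-yl on a saturated chain carbon bound to a saturated ring carbon. Among the measured compounds shown here, the one measured step at this carbon, an at least 8.1-fold lower number from compound 1 to compound 2 (0.91 log units; beyond the scatter), is one in which the triazolyl entered and the number fell, starting from the limit of > 400 ug/mL in this assay, at which 1 of the 2 values shown sits. Taking the triazolyl away again is expected to move the number back up, though formylamino itself is untested and the size is uncertain. Compound 3 is expected at 150 ug/mL (40 ug/mL to 400 ug/mL), a step of a 3.1-fold higher number from compound 2 to compound 3 (0.49 log units; beyond the scatter).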

Compound 3, half-maximal inhibitory concentration: > 400 ug/mL
Compound 3 ended at the assay's limit; the forecaster's own chance of this, stated with the estimate: 30%; at least 2.6-fold (0.42 log units) between middle value and limit.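

Formylamino in place of 1H-1,2,3-triazol-1-yl on a saturated chain carbon bound to a saturated ring carbon gives an at least 8.1-fold higher number from compound 2 to compound 3 (0.91 log units; beyond the scatter). The step from compound 1 to compound 3 cannot be read, as both values are limits. A second group without the triazolyl, formylamino after acetoxy, now sits at the top of the range in this assay, leaving compound 2 alone with a plain number: the limit of > 400 ug/mL in this assay, at which 2 of the 3 values shown sit.

Going by these compounds, whether an imidazol-1-yl ring, an amine or a carboxylic acid at this carbon would also lower the number stays open. On these data alone, the actual numbers of compound 1 and compound 3 remain unknown.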